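A few compounds are considered here, and "the series" means these few. Any claim that something is new, unique, unknown or untested is made for them only; others in the source may bear on it.

Working notes on the series. In a functional assay on HCT-116 cells (Homo sapiens) for inhibition, read by colorimetric assay, with a stated time of 3 days (a lower number here means a stronger inhibitor, a higher number a weaker inhibitor), compound 1 `C/C(=N\O)C(=O)NCCCCCC(=O)Nc1ccccc1` gives > 100000 nM, which is a limit of the assay and not a number. Within the data shown here, compound 3 `CC(C)(C)C(O)(O)C(=O)NCCCCCC(=O)Nc1ccccc1` gives 54400 nM, and compound 2 `O=C(CCCCCCNC(=O)C(O)(O)C(F)(F)F)Nc1cccc2ccccc12` gives 6480 nM, with no measured step linking it to compound 1. Compound 4 `O=C(CCCCCCC(O)C(F)(F)F)Nc1ccccc1` differs from compound 1 by a group of 7 heavy atoms (3 carbon, 1 oxygen, 3 fluorine; no ring) in place of a group of 7 heavy atoms (3 carbon, 2 nitrogen, 2 oxygen; no ring), on a saturated chain carbon, five bonds along the chain from a carbonyl carbon. Among the measured compounds shown here, the only measured step from compound 1 is an at least 1.8-fold lower number from compound 1 to compound 3 (0.26 log units; that floor lies within the scatter), and it changes a different position. With that single guide, a small step toward a lower number is expected in this assay, possibly no larger than the scatter. The expected step is an at least 2.2-fold lower number from compound 1 to compound 4 (0.34 log units; beyond the scatter). For compound 4 the estimated value is 45000 nM, with an expected range of 15000 nM to 100000 nM.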

Compound 4, half-maximal inhibitory concentration: > 40000 nM
Compound 4 gave a limit, no number; the forecaster's own chance of this, stated with the estimate: 35%; the middle value is on the limit's open side.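

Compound 1 and compound 4 each carry a limit, not a number, and no step can be read between them. Going by these compounds, how the 3,3,3-trifluoro-2-hydroxypropyl group of compound 4 compares with the group it replaces stays open.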